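The source may hold more compounds than are shown below. What is called first, only, known or untested is meant among the compounds shown, and "the series" means these compounds.

Measured so far in a functional assay on MCF7 cells (Homo sapiens) for cytotoxicity, read by CCK-8 assay, with a stated time of 48 h; a lower number here means a stronger inhibitor, a higher number a weaker inhibitor:
compound 1, `O=c1oc2ccccc2c(Cl)c1/C=N/c1ccc(S(=O)(=O)Nc2nccs2)cc1`; compound 1 gives 160 nM
compound 2, `N=C(N)NS(=O)(=O)c1ccc(/N=C/c2c(Cl)c3ccccc3oc2=O)cc1`; compound 2 gives 58 nM
compound 3, `Cc1cc(NS(=O)(=O)c2ccc(/N=C/c3c(Cl)c4ccccc4oc3=O)cc2)no1`; compound 3 gives 12 nM

Compound 3 has the lowest number of the three: the steps that lead to it are a 4.8-fold lower number from compound 2 to compound 3 (0.68 log units; beyond the scatter) and a 13-fold lower number from compound 1 to compound 3 (1.12 log units; beyond the scatter), both beyond the scatter. Compound 4 is `Cc1ccnc(NS(=O)(=O)c2ccc(/N=C/c3c(Cl)c4ccccc4oc3=O)cc2)n1`; it differs from compound 3 by 4-methylpyrimidin-2-yl in place of 5-methyl-1,2-oxazol-3-yl on a sulfonamide nitrogen. Among the compounds with values here, no measured pair covers this exact exchange. What bears on it: each measured step alters the same group on the sulfonamide nitrogen, and each moved the number beyond the scatter — a 2.8-fold lower number from compound 1 to compound 2 (0.44 log units; beyond the scatter), a 13-fold lower number from compound 1 to compound 3 (1.12 log units; beyond the scatter), a 4.8-fold lower number from compound 2 to compound 3 (0.68 log units; beyond the scatter). The position is therefore sensitive, but the direction for a new heteroaryl cannot be read from three points. The step is expected to be a 2.5-fold higher number from compound 3 to compound 4 (0.40 log units; beyond the scatter), with a wide range. Compound 4 is expected at 30 nM, between 8 nM and 110 nM.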

Compound 4, half-maximal inhibitory concentration: 31 nM
Estimate against measurement, compound 4: 1.0-fold (0.01 log units) below, within the range that was stated.
By their numbers in this assay, from the lowest: compound 3; then compounds 4 and 2 (each within the scatter of the next); then compound 1.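

In this assay, a six-membered aromatic ring on the sulfonamide nitrogen still improves on 1,3-thiazol-2-yl (a 5.2-fold lower number from compound 1 to compound 4 (0.71 log units; beyond the scatter)), so this place is not limited to five-membered rings. It does not reach 5-methyl-1,2-oxazol-3-yl (a 2.6-fold higher number from compound 3 to compound 4 (0.41 log units; beyond the scatter)), and the ringless group of compound 2 cannot be separated from it (a 1.9-fold lower number from compound 2 to compound 4 (0.27 log units; within the scatter)). Nothing available explains these differences. Open, on these data alone, is what the methyl contributes, with unsubstituted pyrimidin-2-yl as the direct comparison. Also open, as far as these compounds go, is how a plain phenyl ring on the sulfonamide nitrogen would compare.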